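A few compounds are considered here, and "the series" means these few. Any claim that something is new, unique, unknown or untested is made for them only; others in the source may bear on it.

Compound 1 `COc1cc(-c2nccn3cc(-c4ccc(Cl)cc4)nc23)cc(OC)c1OC`: 351 nM
Compound 2 `COc1cc(-c2nccn3cc(-c4ccc(C(F)(F)F)cc4)nc23)cc(OC)c1OC`: > 10000 nM, a limit

Both compounds were tested in a functional assay on HCT-116 cells (Homo sapiens) for inhibition, read by MTT assay, with a stated time of 48 h; on this read-out higher numbers stand for weaker inhibition and lower numbers for stronger inhibition. Compound 2 stands at > 10000 nM, which is a limit of the assay and not a number.

Compound 3 `COc1cc(-c2nccn3cc(-c4ccc(N)cc4)nc23)cc(OC)c1OC` differs from compound 2 by amino in place of trifluoromethyl on an aromatic carbon. Going by the values given here, one measured step bears on this place: an at least 28-fold higher number from compound 1 to compound 2 (1.45 log units; beyond the scatter), which was large and came with trifluoromethyl in place of chloro. Compound 1, which lacks trifluoromethyl, gives 351 nM, but amino itself has not been measured in this series. A large step towards a lower number, meaning stronger inhibition, is therefore expected, estimated as an at least 14-fold lower number from compound 2 to compound 3 (1.15 log units; beyond the scatter). For compound 3 the estimated value is 700 nM, with an expected range from 80 nM to 6000 nM.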

Compound 3, half-maximal inhibitory concentration: 158 nM
The estimate for compound 3 lay 4.4-fold (0.65 log units) above the measured number; the measured number falls inside the stated range.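

In this assay, amino in place of trifluoromethyl at this position gives an at least 63-fold lower number from compound 2 to compound 3 (1.80 log units; beyond the scatter), so a substituent here can restore inhibition on the shared core, and the loss seen so far belongs to trifluoromethyl and not to the position as such. The size of that step is only a bound, since compound 2 stands at a limit and not at a number: the limit of > 10000 nM in this assay, at which 1 of the 3 values shown sits. Amino also goes past chloro, with a 2.2-fold lower number from compound 1 to compound 3 (0.35 log units; beyond the scatter), a modest step that makes compound 3 the strongest of the three.

On these data alone, what stays open is whether a hydroxyl or a methoxy group at this position would match amino or fall back towards chloro. As far as these compounds go, it is equally open whether a dimethylamino group or an acetamide would keep the gain once the amino hydrogens are replaced.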